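A few compounds are considered here, and "the series" means these few. Any claim that something is new, unique, unknown or untested is made for them only; others in the source may bear on it.

In a functional assay on HCT-116 cells (Homo sapiens) for inhibition (a higher number here means that more compound is needed for the effect, a lower number that less compound is needed), compound 1 `COc1cc(N2CCC(C(=O)N3CCOCC3)CC2)ccc1Nc1nc(NC2CCCCC2)c2nc[nH]c2n1` gives 130 nM and compound 2 `COc1cc(N2CCC(CC(=O)N3CCOCC3)CC2)ccc1Nc1nc(NC2CCCCC2)c2nc[nH]c2n1` gives 70 nM. Among the measured compounds shown here, the only measured step, a 1.9-fold lower number from compound 1 to compound 2 (0.27 log units; within the scatter), lies within the scatter, so the two stand level. Compound 3 `COc1cc(N2CCC(CC(=O)N3CCC(N(C)C)C3)CC2)ccc1Nc1nc(NC2CCCCC2)c2nc[nH]c2n1` carries 3-(dimethylamino)pyrrolidin-1-yl in place of morpholin-4-yl on a carbonyl carbon. For the measured compounds named here, no measured step exchanges the morpholin-4-yl, so the expectation rests on compound 2 at 70 nM, and no shift beyond the scatter is expected. The expected step is a 1.2-fold lower number from compound 2 to compound 3 (0.07 log units; within the scatter). Compound 3 is estimated at 60 nM, with an expected range of 20 nM to 200 nM.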

Compound 3, half-maximal effective concentration: 97 nM
The estimate for compound 3 lay 1.6-fold (0.21 log units) below the measured number; the measured number falls inside the stated range.
By their numbers in this assay, from the lowest: compounds 2, 3 and 1 (each within the scatter of the next).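

In this assay, 3-(dimethylamino)pyrrolidin-1-yl in place of morpholin-4-yl on the carbonyl carbon gives a 1.4-fold higher number from compound 2 to compound 3 (0.14 log units; within the scatter) and so does not separate the two groups, although one has a five-membered ring and two nitrogens and the other a six-membered ring with a nitrogen and an oxygen. The combined change gives a 1.3-fold lower number from compound 1 to compound 3 (0.13 log units; within the scatter) and leaves all three compounds level. No evidence is available to explain this. From the compounds shown here alone, whether a piperazine or an open-chain amine on the carbonyl carbon would move the number beyond the scatter stays open.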